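A few compounds are considered here, and "the series" means these few. Any claim that something is new, unique, unknown or untested is made for them only; others in the source may bear on it.

Working notes on the indole ketone hydroxamate series, benzyl-linked benzohydroxamic acid branch.

Compound 1 `O=C(NO)c1ccc(Cn2ccc3cc(C(=O)c4ccc(F)cc4)ccc32)cc1` carries a 4-fluorophenyl ketone on the shared core and a benzyl group bearing the hydroxamic acid. In an assay on isolated protein for inhibition of polyamine deacetylase HDAC10 (Homo sapiens) (on this read-out lower numbers stand for stronger inhibition and higher numbers for weaker inhibition), compound 1 gives > 100000 nM, which is a limit of the assay and not a measured number. This is recorded in the limit of > 100000 nM in this assay, at which 1 of the 3 values shown sits. Compound 1 therefore stands at the weak end of the data shown, with no single number of its own.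

For comparison, compound 2 `COc1ccc(C(=O)c2ccc3c(ccn3S(=O)(=O)c3cccc(/C=C/C(=O)NO)c3)c2)cc1` is a sulfonyl-linked cinnamic hydroxamate and in this assay compound 2 gives 5890 nM. Compound 3 `COc1cc(C(=O)c2ccc3c(ccn3Cc3ccc(/C=C/C(=O)NO)cc3)c2)cc(OC)c1OC` is the benzyl-linked cinnamic hydroxamate with a trimethoxyphenyl ketone; in this assay compound 3 gives "not determined" (no result reported). Neither pair differs from compound 1 in only one place, so no single step can be read from them.

Compound 4 `COc1cccc(C(=O)c2ccc3c(ccn3Cc3ccc(C(=O)NO)cc3)c2)c1` differs from compound 1 by 3-methoxyphenyl in place of 4-fluorophenyl on a carbonyl carbon. The hydroxamic acid, its benzyl attachment and the shared core are unchanged. With compound 1 sitting at a limit, no step beyond the usual scatter is expected in this assay for this exchange, in either direction. For compound 4 the estimate in this assay is 100000 nM, within 30000 nM to 300000 nM, most likely again reported only as a limit, so that the step of a number no higher from compound 1 to compound 4 (the limit leaves the size open) is expected to be no change.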

Compound 4, half-maximal inhibitory concentration: 47900 nM
Estimate against measurement, compound 4: 2.1-fold (0.32 log units) above; low and high end bracket the measured number.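

Going by these compounds alone, the exchange of 4-fluorophenyl for 3-methoxyphenyl on a carbonyl carbon gives the first step that can be read in this branch, an at least 2.0-fold lower number from compound 1 to compound 4 (0.31 log units; beyond the scatter) in this assay. The earlier compounds shown here could not show this, since neither compound 2 nor compound 3 differs from compound 1 in only one place; the group on the carbonyl carbon is now seen to move this read-out beyond the scatter while the hydroxamic acid, its benzyl attachment and the shared core stay unchanged. Only a lower bound can be set on the size of the step, because the value of compound 1 is a limit of the assay: the limit of > 100000 nM in this assay, at which 1 of the 4 values shown sits.

With a single exchange, the compounds shown do not separate what the entering 3-methoxyphenyl contributes from what the leaving 4-fluorophenyl contributes, and they do not say whether the same exchange gives a similar step with a different linker or hydroxamate. Also open, from the compounds shown here alone, is how this read-out responds when an amine or a carboxylic acid stands on the phenyl ring in place of the methoxy group.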